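The compounds below may be only part of what the source reports. "The series", "measured", "known", "first", "only" and "open" are said of these compounds alone.

The shared core carries a thiourea whose nitrogen bears a variable group, and the compounds are compared in a functional assay on HeLa cells (Homo sapiens) for antiproliferative activity, read by sulforhodamine B assay, with a stated time of 72 h; on this read-out lower numbers stand for stronger inhibition and higher numbers for weaker inhibition. Compound 1 `COc1ccccc1NC(=S)N/N=C/c1ccc2ccccc2n1` carries a 2-methoxyphenyl on that nitrogen. In this assay compound 1 reaches only the limit of the measurement, > 100000 nM, which is a limit rather than a number (the limit of > 100000 nM in this assay, at which 1 of the 3 values shown sits). Compound 2 `N#Cc1ccc(NC(=S)N/N=C/c2ccc3ccccc3n2)cc1` carries a 4-cyanophenyl and gives 20000 nM. Compound 3 `S=C(NCc1ccccc1)N/N=C/c1ccc2ccccc2n1` carries a benzyl and gives 62800 nM, the highest of the two numbers shown; the step of a 3.1-fold higher number from compound 2 to compound 3 (0.50 log units; beyond the scatter) is modest and beyond the scatter, while the step of an at least 1.5-fold lower number from compound 1 to compound 3 (0.20 log units; that floor lies within the scatter) has a floor that lies within the scatter.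

Compound 4 `Cc1ccccc1NC(=S)N/N=C/c1ccc2ccccc2n1` differs from compound 3 in one place: 2-methylphenyl in place of benzyl on an amide-type nitrogen. This change brings back a phenyl joined directly to the nitrogen and bearing a group in the 2-position, as in compound 1, whose value is a limit. The step of an at least 1.5-fold lower number from compound 1 to compound 3 (0.20 log units; that floor lies within the scatter) therefore bears on it most closely, and the move from compound 3 to compound 4 is expected to run the other way, towards a higher number, with a real chance that only a limit is reported. For compound 4 the estimate is 100000 nM, with a range from 40000 nM to 250000 nM, meaning an expected step of a 1.6-fold higher number from compound 3 to compound 4 (0.20 log units; within the scatter).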

Compound 4, half-maximal inhibitory concentration: > 100000 nM
Compound 4 was reported as a limit (the forecaster's own chance of this, stated with the estimate: 50%); the middle value lies on the limit itself.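

In this assay, compound 4 is reported only as a limit, and replacing benzyl with 2-methylphenyl on this nitrogen gives an at least 1.5-fold higher number from compound 3 to compound 4 (0.20 log units; that floor lies within the scatter); that floor lies within the scatter, so this step alone does not establish a real loss of activity. The firmer result is an at least 5.0-fold higher number from compound 2 to compound 4 (0.69 log units; beyond the scatter), which shows that 2-methylphenyl on this nitrogen gives a weaker result than 4-cyanophenyl by more than the scatter, as the earlier step from compound 1 to compound 2 showed for 2-methoxyphenyl. Compound 1 and compound 4 both stop at the limit, so the step between them cannot be read and methyl cannot be told apart from methoxy on this evidence: the limit of > 100000 nM in this assay, at which 2 of the 4 values shown sit.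

As far as these compounds go, what remains open is whether the better result for compound 2 comes from the nitrile itself or from the 4-substituted phenyl more generally, a question that a plain phenyl, a 4-methylphenyl or a 4-methoxyphenyl on this nitrogen could help to settle. A 2-cyanophenyl could show how the same nitrile behaves as a 2-substituent, and a 2-phenylethyl could extend the comparison with the benzyl of compound 3.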